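Compound 1 to compound 3: methoxy for 4-methylpiperazin-1-yl

This account rests on a few compounds, and the source may have more. Where it says the series, first, only, none or still open, it means among the compounds named here.

- compound 1 `CN1CCN(C(=O)/C=C/c2ccncc2-c2ccc3ccccc3c2)CC1` gives > 10000 nM as a limit
- compound 2 `O=C(/C=C/c1ccncc1-c1ccc2cc[nH]c2c1)N1CCOCC1` gives > 10000 nM as a limit

In a functional assay on MCF7 cells (Homo sapiens) for inhibition, read by sulforhodamine B assay, with a stated time of 72 h (on this read-out higher numbers stand for weaker inhibition of growth and lower numbers for stronger inhibition of growth), compound 1 gives > 10000 nM, which is a limit and not a number. Compound 2 gives > 10000 nM, also a limit. For the measured compounds named here, compound 1 therefore stands with compound 2 at the limit of > 10000 nM in this assay, at which 2 of the 2 values shown sit, and the series offers no measured step.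

Compound 3 `COC(=O)/C=C/c1ccncc1-c1ccc2ccccc2c1` is not yet measured. It differs from compound 1 by methoxy in place of 4-methylpiperazin-1-yl on a carbonyl carbon, with methoxy in place of 4-methylpiperazin-1-yl on a carbonyl carbon. No shown step sizes this change, so the expectation in this assay is for no shift beyond the scatter, and any shift would more likely be toward stronger inhibition of growth. The expected change is a step that the limit leaves unreadable from compound 1 to compound 3 in this estimate. For compound 3 the estimated value is 15000 nM, with an expected range from 5000 nM to 40000 nM in this read-out.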

Compound 3, concentration for 50% growth inhibition: 8170 nM
The estimate for compound 3 lay 1.8-fold (0.26 log units) above the measured number, within the range that was stated.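

Methoxy on the carbonyl carbon yields the first number in the series in this assay, whereas the other compounds shown remain at a limit: the limit of > 10000 nM in this assay, at which 2 of the 3 values shown sit. Replacing 4-methylpiperazin-1-yl with methoxy gives an at least 1.2-fold lower number from compound 1 to compound 3 (0.08 log units; that floor lies within the scatter), so the change points toward stronger inhibition of growth but is not shown to exceed the scatter. The result does show that a measurable number at this carbonyl carbon does not require 4-methylpiperazin-1-yl, although the true size of the step cannot be read while compound 1 stands at a limit.

Still open, on these data alone, is how a carboxylic acid, or an ethoxy or longer alkoxy chain, on this carbonyl carbon would read against compound 3. Also open, as far as these compounds go, is whether a small amine such as dimethylamino would read as a number or stay at the limit.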